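The source may hold more compounds than are shown below. What is called first, only, known or untested is meant among the compounds shown, and "the series" means these compounds.

Compound 1 `C=CCOC1=CC(=O)S[C@]1(C)CCCCCC`: in a functional assay on MCF7 cells (Homo sapiens) for inhibition (on this read-out higher numbers stand for weaker inhibition and lower numbers for stronger inhibition), compound 1 gives > 50 ug/mL, which is a limit of the assay.
Compound 2 `C=CCOC1=CC(=O)S[C@]1(C)CCCCCCCC`: in this assay compound 2 gives > 50 ug/mL, again a limit of the assay.
Compound 3 `CCCCCC[C@@]1(C)SC(=O)C=C1OCC(=O)NCCCBr`: in this assay compound 3 gives 6.7 ug/mL.

Compound 2 thus stands at the limit of > 50 ug/mL in this assay, at which 2 of the 3 values shown sit, and the step that the two limits leave unreadable from compound 1 to compound 2, which puts ethyl in place of hydrogen on a saturated chain carbon, six bonds along the chain from a saturated ring carbon, cannot be read. Compound 4 `C=CCOC(=O)OC1=CC(=O)S[C@]1(C)CCCCCCCC` differs from compound 2 by allyloxycarbonyl in place of allyl on an oxygen on an unsaturated carbon. For the measured compounds named here, the one readable step touches the same oxygen: an at least 7.4-fold lower number from compound 1 to compound 3 (0.87 log units; beyond the scatter), where (3-bromopropyl)carbamoyl took the place of vinyl on a saturated chain carbon bound to an oxygen on an unsaturated carbon. That change brought a carbonyl into the group on this oxygen and gave a lower number; the change to compound 4 also brings a carbonyl into that group, though a different one. A step toward lower numbers in this assay is therefore expected, of unreadable size because compound 2 sits at a limit, and the step of an at least 2.5-fold lower number from compound 2 to compound 4 (0.39 log units; beyond the scatter) is the estimate. Compound 4 is expected to give about 20 ug/mL, between 5 ug/mL and 50 ug/mL.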

Compound 4, half-maximal inhibitory concentration: 14.2 ug/mL
Beside the measured number, compound 4's estimate is 1.4-fold (0.15 log units) above it; low and high end bracket the measured number.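

Putting allyloxycarbonyl in place of allyl on an oxygen on an unsaturated carbon gives an at least 3.5-fold lower number from compound 2 to compound 4 (0.54 log units; beyond the scatter) in this assay, so changing the group on this oxygen yields a readable value on the core of compound 2 as well as on the core of compound 1. The entering group holds no bromine and, by its count, 0 hydrogen-bond donors, so on the core of compound 2 a value inside the range of the assay needs neither of them. Compound 2 sits at a limit of the assay, and for that reason the step gives only a lower bound on the change: the limit of > 50 ug/mL in this assay, at which 2 of the 4 values shown sit.

On these data alone, whether the step belongs to the carbonyl or to the allyl end of the entering group stays open, a question that an acetyl or a methoxycarbonyl on this oxygen would address. Also open, as far as these compounds go, are how allyloxycarbonyl behaves on the core of compound 1 and whether an amine or a carboxylic acid at the end of the group on this oxygen would shift the number further.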